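The source may report more compounds than this note shows. Statements on the series, on what has been measured and on what is new or still open speak of the compounds shown alone.

Measured so far:
compound 1 `CCCCO[C@H](c1ccc(O)c(O)c1)[C@H](CC#Cc1ccc(O)c(O)c1)O[C@@H]1O[C@H](CO)[C@@H](O)[C@H](O)[C@H]1O`: 96.8%
compound 2 `CCCCO[C@@H](c1ccc(O)c(O)c1)[C@H](CC#Cc1ccc(O)c(O)c1)O[C@@H]1O[C@H](CO)[C@@H](O)[C@H](O)[C@H]1O`: 100%
compound 3 `OC[C@H]1O[C@@H](O[C@@H](CC#Cc2ccc(O)c(O)c2)[C@H](O)c2ccc(O)c(O)c2)[C@H](O)[C@@H](O)[C@@H]1O`: 83.6%

In a functional assay on heart right ventricle (Rattus norvegicus, strain WKY), tested at 3 uM (a higher number here means a weaker effect of the compound at the concentration tested, a lower number a stronger effect), compound 3 gives the lowest number of the three; compound 1 lies nearest to it and compound 2 furthest, both gaps beyond the scatter. Compound 4 `OC[C@H]1O[C@@H](O[C@@H](CC#Cc2ccc(O)cc2)[C@H](O)c2ccc(O)c(O)c2)[C@H](O)[C@@H](O)[C@@H]1O` differs from compound 3 by hydrogen in place of hydroxy on an aromatic carbon. Neither measured step touches an aromatic hydroxy: a number 3.2 percentage points higher from compound 1 to compound 2 (within the scatter) rests on configuration alone (the fact that compounds 1 and 2 differ only in the configuration as drawn), and a number 13.2 percentage points lower from compound 1 to compound 3 (beyond the scatter) concerns the butyl ether on a saturated carbon. Going by the values given here, no measured step therefore bears directly on the change to compound 4; the one step beyond the scatter is modest, so a step of no more than modest size is expected, with the direction open. Compound 4 is estimated at 88% (range 75% to 100%), which is an expected a number 4.4 percentage points higher from compound 3 to compound 4 (within the scatter).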

Compound 4, a percentage reported as activity, at one concentration (the size of the read-out at that concentration, not a potency): 99.2%
Estimate against measurement, compound 4: 11.2 percentage points below, and the stated range covers the measured number.
By their numbers in this assay, from the lowest: compound 3; then compounds 1, 4 and 2 (each within the scatter of the next).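

In this assay, going by these compounds alone, the change from 3,4-dihydroxyphenyl to 4-hydroxyphenyl gives a number 15.6 percentage points higher from compound 3 to compound 4 (beyond the scatter) and is the first measured step at an aromatic position. At the concentration tested, this hydroxy therefore matters: the effect is weaker without it. No available evidence explains this step.

On these data alone, whether a methoxy group or an amine in this position would keep the effect remains open. So does the contribution of the remaining hydroxy on this ring and of the hydroxy groups on the other aromatic ring.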